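Methoxy to hydroxy on compound 2

This account rests on a few compounds, and the source may have more. Where it says the series, first, only, none or still open, it means among the compounds named here.

Values in a functional assay on HT-29 cells (Homo sapiens) for inhibition, read by MTT assay, with a stated time of 48 h; on this read-out lower numbers stand for stronger inhibition and higher numbers for weaker inhibition:
- compound 1 `COc1ccc(-c2cc(-c3cc(OC)c(OC)c(OC)c3)nc(-c3ccccc3)n2)c(OC)c1`: > 25000 nM (a limit of the assay)
- compound 2 `COc1ccc(-c2cc(-c3cc(OC)c(OC)c(OC)c3)nc(-c3ccccc3)n2)cc1`: 4230 nM

The value of compound 1, > 25000 nM, is a limit and not a number. Going by the values given here, compound 2, at 4230 nM, therefore carries the only actual number in this assay.

Compound 3 `COc1cc(-c2cc(-c3ccc(O)cc3)nc(-c3ccccc3)n2)cc(OC)c1OC` comes from compound 2 by one change: hydrogen in place of methyl on an oxygen on an aromatic ring. This is hydrogen in place of methyl on an oxygen on an aromatic ring, methoxy to hydroxy, or 4-methoxyphenyl to 4-hydroxyphenyl.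

Among the compounds with values here, the only measured step is an at least 5.9-fold lower number from compound 1 to compound 2 (0.77 log units; beyond the scatter). That step starts from the limit of > 25000 nM in this assay, at which 1 of the 2 values shown sits. It is hydrogen in place of methoxy on an aromatic carbon, a different change from the one here, so it gives only weak guidance on size and direction.

Within the data shown here, with no measured step of the present kind, the expected outcome is no step beyond the scatter, and the estimated step is a 1.2-fold lower number from compound 2 to compound 3 (0.08 log units; within the scatter). The range is kept wide on that account. For compound 3 the expected value is 3500 nM, with an estimated range of 900 nM to 14000 nM.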

Compound 3, half-maximal inhibitory concentration: 11300 nM
Compound 3: middle estimate off by 3.2-fold (0.51 log units), on the low side; low and high end bracket the measured number.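

In this assay, the 4-hydroxyphenyl does not hold the level of the 4-methoxyphenyl: hydrogen in place of methyl on an oxygen on an aromatic ring gives a 2.7-fold higher number from compound 2 to compound 3 (0.43 log units; beyond the scatter), so this methyl has a modest but real bearing on the read-out. Compound 2 now has the lowest number of the three, with its steps to both other compounds beyond the scatter, while the 4-hydroxyphenyl in compound 3 still compares favourably with the 2,4-dimethoxyphenyl in compound 1, with an at least 2.2-fold lower number from compound 1 to compound 3 (0.34 log units; beyond the scatter). The value of compound 1 is a limit and not a number, so this last step gives only a minimum size: the limit of > 25000 nM in this assay, at which 1 of the 3 values shown sits.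

The compounds shown hold only methoxy and hydroxy on this oxygen-bearing carbon of the ring, so it remains open whether a longer chain such as ethoxy, or an amine in place of the oxygen, would move the number further in either direction. From the compounds shown here alone, the same change on the other methoxy groups of the shared core also remains open, and the size of this step may not carry over to them.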